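The source may report more compounds than this note shows. Statements on the series, on what has been measured and on what is new or still open speak of the compounds shown alone.

In an ADME assay on THP-1 cells (Homo sapiens) for cytotoxicity, read by MTT assay (a higher number here means that more compound is tolerated, a lower number that less compound is tolerated), compound 1 (`Cc1nc(-c2cccnc2)sc1-c1nnc(-c2ccc(Br)cc2)o1`) gives > 100 ug/mL as its result, and this is a limit, not a number. Compound 2 (`Cc1nc(-c2cccnc2)sc1-c1nnc(-c2ccc([N+](=O)[O-])cc2)o1`) gives > 100 ug/mL as its result, again only a limit. All the evidence so far is the limit of > 100 ug/mL in this assay, at which 2 of the 2 values shown sit, and no exact number.

Compound 3 (`COc1ccccc1-c1nnc(-c2sc(-c3cccnc3)nc2C)o1`) keeps the core of compound 1 and differs in one place (2-methoxyphenyl in place of 4-bromophenyl on an aromatic carbon), with 2-methoxyphenyl in place of 4-bromophenyl on an aromatic carbon of a five-membered aromatic ring with 2 nitrogen and 1 oxygen. For the measured compounds named here, the only measured step that bears on this is a step that the two limits leave unreadable from compound 1 to compound 2 and it alters the same 4-bromophenyl group, though it gives no size to carry over. For compound 3 no step beyond the scatter is therefore expected in this assay and no direction can be named. The expected change is a number no higher from compound 1 to compound 3 (the limit leaves the size open) and this remains an estimate. For compound 3 the estimated half-maximal cytotoxic concentration is 100 ug/mL with an expected range from 40 ug/mL to 200 ug/mL and a limit may well be expected again.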

Compound 3, half-maximal cytotoxic concentration: > 100 ug/mL
Compound 3 gave a limit, no number (the forecaster's own chance of this, stated with the estimate: 75%); the middle value sits exactly at the limit.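

For the compounds shown here, compound 1 and compound 3 each give only a limit, not a number, so no step between them can be read: the limit of > 100 ug/mL in this assay, at which 3 of the 3 values shown sit. The compounds shown leave open the concentration at which any of them reaches its half-maximal cytotoxic effect in this assay, and whether changing the 4-bromophenyl group makes any difference there.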